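Trimethoxyphenyl Benzimidazoles Against A549 Cells: A Methoxy Variant

The source may report more compounds than this note shows. Statements on the series, on what has been measured and on what is new or still open speak of the compounds shown alone.

Compound 1 `COc1cc(-n2cnc3ccc(-c4ccc([N+](=O)[O-])cc4)cc32)cc(OC)c1OC`: 8940 nM
Compound 2 `COc1cc(-n2cnc3ccc(-c4cccc(F)c4)cc32)cc(OC)c1OC`: 5270 nM
Compound 3 `COc1cc(-n2cnc3ccc(-c4ccc(Cl)cc4)cc32)cc(OC)c1OC`: > 10000 nM

All three compounds were tested in a functional assay on A549 cells (Homo sapiens) for antiproliferative activity, read by MTT assay, with a stated time of 72 h; a lower number here means a stronger inhibitor, a higher number a weaker inhibitor. For compound 3 the result is a limit of this assay, not a number, namely > 10000 nM; this is the point (the limit of > 10000 nM in this assay, at which 1 of the 3 values shown sits). Compound 4 `COc1cccc(-c2ccc3ncn(-c4cc(OC)c(OC)c(OC)c4)c3c2)c1` has not yet been measured. It differs from compound 3 in one place: 3-methoxyphenyl in place of 4-chlorophenyl on an aromatic carbon. Within the data shown here, two measured steps bear on this change. The step of an at least 1.8-fold higher number from compound 2 to compound 3 (0.27 log units; that floor lies within the scatter) and the step of an at least 1.1-fold higher number from compound 1 to compound 3 (0.04 log units; that floor lies within the scatter) both end at the limit, and neither floor exceeds the scatter. The new change is therefore expected to give, at most, a step of the size an at least 1.4-fold lower number from compound 3 to compound 4 (0.15 log units; that floor lies within the scatter), in the direction of a lower number. Compound 4 is estimated at 7000 nM, with a range from 3000 nM to 20000 nM.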

Compound 4, half-maximal inhibitory concentration: 3180 nM
For compound 4 the middle estimate is 2.2-fold (0.34 log units) above the measured one; the measured number falls inside the stated range.
By their numbers in this assay, from the lowest: compounds 4, 2 and 1 (each within the scatter of the next, the first and the last beyond it). At a limit, above all of these: compound 3.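

In this assay, among these compounds, 3-methoxyphenyl at this position gives the first steps that clear the scatter: an at least 3.1-fold lower number from compound 3 to compound 4 (0.49 log units; beyond the scatter), and a 2.8-fold lower number from compound 1 to compound 4 (0.45 log units; beyond the scatter). For compound 3 the value is a limit of the assay, not a number: the limit of > 10000 nM in this assay, at which 1 of the 4 values shown sits. Methoxy in place of fluoro separates nothing, with a 1.7-fold lower number from compound 2 to compound 4 (0.22 log units; within the scatter).

The compounds shown leave open how an amine or a carboxylic acid on this phenyl ring would read. They also do not separate the kind of group from its place on the ring, with chloro and methoxy differing in both.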